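The compounds below may be only part of what the source reports. "The series", "measured", "known", "first", "only" and "open" are said of these compounds alone.

Measured compounds in an assay on isolated protein for binding affinity to sphingosine 1-phosphate receptor 2 (Homo sapiens), read by surface plasmon resonance; on this read-out higher numbers stand for weaker binding and lower numbers for tighter binding:
compound 1, `Cn1nc(C(F)(F)F)c2c(-c3ccccc3)cc(NNC(=O)Nc3cc(Cl)nc(Cl)c3)nc21`, gives 940 nM
compound 2, `Cn1ncc2c(-c3ccccc3)cc(NNC(=O)Nc3cc(Cl)nc(Cl)c3)nc21`, gives 1020 nM
compound 3, `Cc1nn(C)c2nc(NNC(=O)Nc3cc(Cl)nc(Cl)c3)cc(-c3ccccc3)c12`, gives 5320 nM

Compound 1 has the lowest number of the three. Its nearest neighbour is compound 2: the step of a 1.1-fold higher number from compound 1 to compound 2 (0.04 log units; within the scatter) lies within the scatter, so these two cannot be ordered. The step of a 5.7-fold higher number from compound 1 to compound 3 (0.75 log units; beyond the scatter) and the step of a 5.2-fold higher number from compound 2 to compound 3 (0.72 log units; beyond the scatter) both lie beyond the scatter, and compound 3 stands furthest from compound 1.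

Compound 4, `CCCc1cc(NNC(=O)Nc2cc(Cl)nc(Cl)c2)nc2c1c(C(F)(F)F)nn2C`, differs from compound 1 in one place: propyl in place of phenyl on an aromatic carbon. The group that leaves is phenyl, the group that enters is propyl, at a position opposite the ring nitrogen and ortho to a fused ring. All three measured steps concern the trifluoromethyl position of the shared core, and none of them touches the position changed here. Among the compounds with values here, there is thus no measured step that bears on this change, and no size or direction can be read from the series; the expectation rests on the change itself and carries a wide range.

For compound 4 in this assay the estimated value is 2500 nM, expected to fall between 600 nM and 12000 nM. The step this estimate implies, a 2.7-fold higher number from compound 1 to compound 4 (0.42 log units; beyond the scatter), is an expectation only and is weakly held.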

Compound 4, dissociation constant: 890 nM
Compound 4: middle estimate off by 2.8-fold (0.45 log units), on the high side, and the stated range covers the measured number.
By their numbers in this assay, from the lowest: compounds 4, 1 and 2 (each within the scatter of the next); then compound 3.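

In this assay, propyl in place of phenyl at the position opposite the ring nitrogen gives a 1.1-fold lower number from compound 1 to compound 4 (0.02 log units; within the scatter), so this pair cannot be ordered on this read-out. The earlier compounds shown here all carry phenyl here and could say nothing about this position; with trifluoromethyl held on the shared core, this pair now shows that an open propyl chain can stand in place of a six-membered aromatic ring of carbon only without a step beyond the scatter. Nothing at hand accounts for why the two groups read alike.

On these data alone, whether propyl would read the same with hydrogen or methyl in place of trifluoromethyl stays open, which matters given the gap that methyl opens in the phenyl series. Also open, as far as these compounds go, is how far this tolerance extends, since one pair sets no pattern: an ethyl group, a longer chain such as butyl, an amine or a carboxylic acid at this position could each read differently in this assay.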